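Chloro to Methyl on the Aryl Group of Compound 1

A few compounds are considered here, and "the series" means these few. Any claim that something is new, unique, unknown or untested is made for them only; others in the source may bear on it.

Measured so far:
compound 1 `OC[C@H]1C[C@@H](Cn2cnc3c(-c4ccc(Cl)cc4)ncnc32)c2ccccc21`: 0.63 ug/mL
compound 2 `CCOc1ncnc2c1ncn2C[C@@H]1C[C@H](CO)c2ccccc21`: 24 ug/mL
compound 3 `CCCNc1ncnc2c1ncn2C[C@@H]1C[C@H](CO)c2ccccc21`: 24 ug/mL

In a functional assay on CCRF-CEM cells (Homo sapiens) (a lower number here means a stronger inhibitor, a higher number a weaker inhibitor), compound 1 gives the lowest of the three numbers. Replacing its 4-chlorophenyl is costly: a 38-fold higher number from compound 1 to compound 2 (1.58 log units; beyond the scatter) and a 38-fold higher number from compound 1 to compound 3 (1.58 log units; beyond the scatter), while no change at the digits printed from compound 2 to compound 3 (within the scatter). Compound 4 `Cc1ccc(-c2ncnc3c2ncn3C[C@@H]2C[C@H](CO)c3ccccc32)cc1` keeps the aryl ring and alters only its substituent: methyl in place of chloro on an aromatic carbon. Within the data shown here, no measured step touches this substituent; the known steps show only that removing the whole ring weakens inhibition strongly. A change of one atom on a retained ring is expected to move the number little, so for compound 4 the expected step is a 1.3-fold higher number from compound 1 to compound 4 (0.10 log units; within the scatter), within the scatter. Compound 4 is therefore estimated at 0.8 ug/mL, between 0.3 ug/mL and 2.5 ug/mL.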

Compound 4, half-maximal inhibitory concentration: 1.4 ug/mL
Estimate against measurement, compound 4: 1.8-fold (0.24 log units) below; low and high end bracket the measured number.
By their numbers in this assay, from the lowest: compound 1; then compound 4; then compounds 2 and 3 (each within the scatter of the next).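

Chloro and methyl are not interchangeable on this ring: there is a 2.2-fold higher number from compound 1 to compound 4 (0.35 log units; beyond the scatter) and so the substituent matters, though only modestly. The aryl ring itself counts for far more, since keeping it with methyl still gives a 17-fold lower number from compound 3 to compound 4 (1.23 log units; beyond the scatter) and likewise a 17-fold lower number from compound 2 to compound 4 (1.23 log units; beyond the scatter) when ethoxy is the group replaced. Together these steps show that the substituent tunes a large gain that comes with the ring.

Nothing available explains the gap between chloro and methyl. On these data alone, whether fluoro, methoxy, trifluoromethyl or a bare phenyl ring would sit nearer compound 1 or compound 4 stays open.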